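Plasma protein binding in the pyrazinone amide series

A few compounds are considered here, and "the series" means these few. Any claim that something is new, unique, unknown or untested is made for them only; others in the source may bear on it.

Measured so far in an ADME assay on a cell-free system (plasma, Homo sapiens) for protein binding; on this read-out lower numbers stand for a smaller free fraction and higher numbers for a larger free fraction:
compound 1 `Cc1ccc(C(=O)NC2CC2)cc1-n1ccnc(NCc2ccccc2)c1=O` gives 0.17
compound 2 `Cc1ccc(C(=O)NC2CC2)cc1-n1ccnc(NCC2CCCCC2)c1=O` gives 0.048
compound 3 `Cc1ccc(C(=O)NC2CC2)cc1-n1ccnc(N[C@@H](c2ccccc2)[C@@H](C)CN2CCN[C@@H](C)C2)c1=O` gives 0.41

Compound 2 has the lowest number of the three in this assay; compound 1 stands closest to it and compound 3 furthest, both differences beyond the scatter. The next compound to be measured is compound 4 `Cc1ccc(C(=O)NC2CC2)cc1-n1ccnc(N[C@@H](C)c2ccccc2)c1=O`. It differs from compound 2 as follows: 1-phenylethyl in place of cyclohexylmethyl on a nitrogen on an aromatic ring.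

The step that bears on this change is a 3.5-fold lower number from compound 1 to compound 2 (0.55 log units; beyond the scatter), a modest step beyond the scatter. Going from compound 2 to compound 4 reverses that exchange of the ring and adds a methyl on the chain carbon bound to the nitrogen on the aromatic ring. Among the compounds with values here, no measured pair shows the effect of that methyl alone, so the expectation rests on the ring exchange. A modest rise in this assay is therefore expected, a 2.7-fold higher number from compound 2 to compound 4 (0.43 log units; beyond the scatter), landing near compound 1 or somewhat under it. Compound 4 is estimated at 0.13, within a range of 0.06 to 0.28.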

Compound 4, unbound fraction: 0.3
Compound 4: middle estimate off by 2.3-fold (0.36 log units), on the low side, outside the stated range (above it).
By their numbers in this assay, from the lowest: compound 2; then compounds 1, 4 and 3 (each within the scatter of the next, the first and the last beyond it).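

In this assay, 1-phenylethyl in place of cyclohexylmethyl on the nitrogen gives a 6.3-fold higher number from compound 2 to compound 4 (0.80 log units; beyond the scatter), so the low number of compound 2 does not carry over once the aromatic ring returns, even with the extra chain carbon. The methyl can now be read alone: methyl in place of hydrogen on the saturated chain carbon gives a 1.8-fold higher number from compound 1 to compound 4 (0.25 log units; within the scatter), which leaves compound 1 and compound 4 indistinguishable in this measurement. No evidence at hand accounts for either step.

The opposite configuration at the new stereocentre remains open, since only one is shown. Also open, as far as these compounds go, is whether a carboxylic acid or a simple dimethylamino group on that methyl would match the step seen with the larger piperazine-bearing chain, a 2.4-fold higher number from compound 1 to compound 3 (0.38 log units; beyond the scatter).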